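The source may report more compounds than this note shows. Statements on the series, on what has been measured and on what is new or still open speak of the compounds shown alone.

Measured so far:
compound 1, `C#CCN(c1nc(-c2cccc(Br)c2)no1)C1CCCCC1` — 53.5 ug/mL
compound 2, `CC(=O)OC[C@H]1O[C@H](OC[C@@H](Cn2cc(CN(c3nc(-c4ccc([N+](=O)[O-])cc4)no3)C3CCCCC3)nn2)OC(C)=O)C=C[C@@H]1OC(C)=O` — > 200 ug/mL

The read-out here is an ADME assay on HepG2 cells (Homo sapiens) for cytotoxicity, read by MTT assay, with a stated time of 48 h; on this read-out higher numbers stand for lower toxicity in this test and lower numbers for higher toxicity in this test. In this assay compound 1 gives 53.5 ug/mL, a plain number. For compound 2 the assay reports no number, only a limit, > 200 ug/mL. Compound 2 therefore stands at the limit of > 200 ug/mL in this assay, at which 1 of the 2 values shown sits, so its true value is known only to lie on the far side of that limit. The next compound, compound 3 `CC(=O)OC[C@H]1O[C@H](OC[C@@H](Cn2cc(CN(c3nc(-c4ccc(C)cc4)no3)C3CCCCC3)nn2)OC(C)=O)C=C[C@@H]1OC(C)=O`, differs from compound 2 in one place: methyl in place of nitro on an aromatic carbon. Within the data shown here, no two measured compounds differ in one place, so there is no measured step of this kind to lean on. Starting from a limit, the step from compound 2 to compound 3 is expected to be a number no higher from compound 2 to compound 3 (the limit leaves the size open), that is, nothing beyond the usual scatter. Compound 3 is expected to give about 200 ug/mL, most likely between 100 ug/mL and 400 ug/mL, with a good chance that only a limit is reported again.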

Compound 3, half-maximal cytotoxic concentration: 36.8 ug/mL
Estimate against measurement, compound 3: 5.4-fold (0.74 log units) above; measured number below the stated range.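

In this assay, replacing 4-nitrophenyl with 4-methylphenyl gives an at least 5.4-fold lower number from compound 2 to compound 3 (0.73 log units; beyond the scatter), a step beyond the usual scatter. Among these compounds, this is the first sign that the group on this aromatic carbon, para to a large group, matters in this test: the two structures differ nowhere else, and the lower number marks compound 3 as the more toxic of the pair. The true size of the step stays unknown, because compound 2 has no plain number, only a limit: the limit of > 200 ug/mL in this assay, at which 1 of the 3 values shown sits.

A single swap cannot show whether nitro lowers the toxicity or methyl raises it, since the compounds shown include no version with a plain hydrogen at this carbon. Where a methoxy group, an amine or a carboxylic acid in this place would fall also remains open.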